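Thioester in place of a chlorophenyl ester

The source may report more compounds than this note shows. Statements on the series, on what has been measured and on what is new or still open speak of the compounds shown alone.

Compound 1 `CC(=O)OCc1ccc2oc(=O)c(C(=O)Oc3cccc(Cl)c3)cc2c1` is the weaker of the two measured compounds in a functional assay on HT-1080 cells (Homo sapiens), read by transwell migration, with a stated time of 24 h, tested at 0.1 uM; on this read-out lower numbers stand for a stronger effect and higher numbers for a weaker effect at the one concentration tested: compound 1 gives 95.2%, the highest of the two numbers shown. Its nearest neighbour, compound 2 `CC(=O)OCc1ccc2oc(=O)c(C(=O)Oc3cccc(Br)c3)cc2c1`, gives 39.5% in this assay, and the change of bromo in place of chloro on an aromatic carbon lowers the read-out by a number 55.7 percentage points lower from compound 1 to compound 2 (beyond the scatter). Compound 3 `CC(=O)OCc1ccc2oc(=O)c(C(=O)Sc3ccccc3)cc2c1` differs from compound 1 as follows: phenylsulfanyl in place of 3-chlorophenoxy on a carbonyl carbon. Within the data shown here, no measured step touches this part of the molecule; the only step known, a number 55.7 percentage points lower from compound 1 to compound 2 (beyond the scatter), concerns a halogen swap, so it offers no direct guide. Compound 3 is therefore expected to lie somewhere between the two measured numbers in this assay, with a wide range, as a step of a number 30.2 percentage points lower from compound 1 to compound 3 (beyond the scatter). The estimate for compound 3 is 65%, within 30% to 100%.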

Compound 3, a percentage reported as activity, at one concentration (the size of the read-out at that concentration, not a potency): 89.5%
The estimate for compound 3 lay 24.5 percentage points below the measured number; low and high end bracket the measured number.
By their numbers in this assay, from the lowest: compound 2; then compounds 3 and 1 (each within the scatter of the next).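

Putting phenylsulfanyl in place of 3-chlorophenoxy on the carbonyl carbon gives a number 5.7 percentage points lower from compound 1 to compound 3 (within the scatter) in this assay and so, for the first time among the compounds shown, alters the group on this carbonyl carbon as a whole, replacing the oxygen link with sulfur and removing the chlorine, with no change beyond the scatter. Against the bromo compound, the same place shows a number 50 percentage points higher from compound 2 to compound 3 (beyond the scatter) and thus compound 3 does not share the stronger effect of compound 2, which is the only one of the three that stands apart from the others. Nothing available here bears on why the read-out follows this pattern.

The compounds shown leave open whether a 3-bromophenylsulfanyl group would keep the effect of compound 2. They also leave open how a 3-iodophenoxy group or an anilide on the same carbonyl carbon would behave.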